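The source may hold more compounds than are shown below. What is called first, only, known or untested is meant among the compounds shown, and "the series" means these compounds.

Measured so far:
- compound 1, `O=C(O)CN1C(=O)/C(=C/C2=Cc3ccccc3OC2)SC1=S`: > 100000 nM
- compound 2, `O=C1NC(=S)S/C1=C\C1=Cc2cc(Br)ccc2OC1`: 51000 nM

Within the data shown here, in a functional assay on A549 cells (Homo sapiens) for antiproliferative activity, read by MTT assay, with a stated time of 72 h (a higher number here means a weaker inhibitor, a lower number a stronger inhibitor), compound 2 gives 51000 nM, the only plain number among the two values shown. For compound 1 the reading is a limit of the assay rather than a number, > 100000 nM, as described in the limit of > 100000 nM in this assay, at which 1 of the 2 values shown sits. Compound 3, `O=C(O)CN1C(=O)/C(=C/C2=Cc3cc(Br)ccc3OC2)SC1=S`, is still unmeasured; it keeps the bromine of compound 2 and differs from it by carboxymethyl in place of hydrogen on an amide-type nitrogen in a ring. Compound 1 carries that same carboxymethyl group without the bromine, and its reading sits at the limit, while compound 2 without the group gives a number. Among the measured compounds shown here, with no measured step for this change, only a weakening beyond the usual scatter is expected. Compound 3 is estimated at 90000 nM, within a range from 35000 nM to 250000 nM, and the expected step is a 1.8-fold higher number from compound 2 to compound 3 (0.25 log units; within the scatter).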

Compound 3, half-maximal inhibitory concentration: > 25000 nM
Compound 3: no number, only a limit (the forecaster's own chance of this, stated with the estimate: 45%); the middle value lies beyond the limit too.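

In this assay compound 3 gives only a limit of the assay, > 25000 nM, not a number. Its steps from compound 2 and from compound 1 therefore cannot be read. Still open, from the compounds shown here alone, is how far carboxymethyl on the amide-type nitrogen, or bromo on the aromatic carbon, moves the reading.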